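Sulfonamide nitrogen substituent: from compound 2 to compound 4

The source may hold more compounds than are shown below. What is called first, only, known or untested is meant among the compounds shown, and "the series" means these compounds.

Measured so far in a functional assay on DU-145 cells (Homo sapiens) for antiproliferative activity, read by sulforhodamine B assay, with a stated time of 72 h (a higher number here means a weaker inhibitor, a lower number a stronger inhibitor), as follows:
- compound 1 `CCN1C(=O)CS/C1=N/Nc1nncc2ccccc12` gives 86 nM
- compound 2 `O=S(=O)(Nc1ncccn1)c1ccc(Nc2nncc3ccccc23)cc1` gives 45 nM
- compound 3 `O=C1CS/C(=N/Nc2nncc3ccccc23)N1` gives 67 nM

Compound 2 stands within the scatter of both compound 1 and compound 3, so no order can be drawn among the three. Compound 4 `O=S(=O)(Nc1ccccn1)c1ccc(Nc2nncc3ccccc23)cc1` differs from compound 2 in one place, with pyridin-2-yl in place of pyrimidin-2-yl on a sulfonamide nitrogen and the rest unchanged. For the measured compounds named here, the only measured step between close relatives (a 1.3-fold lower number from compound 1 to compound 3 (0.11 log units; within the scatter)) lies within the scatter, but it is hydrogen in place of ethyl on an amide-type nitrogen in a ring, at a different place. Going by the values given here, no measured step touches the sulfonamide nitrogen, so this step offers only weak guidance. No step beyond the scatter is expected in this assay and no direction is claimed. The expected step is small (a 1.1-fold higher number from compound 2 to compound 4 (0.05 log units; within the scatter)). In this assay compound 4 is estimated at 50 nM (expected range 20 nM to 125 nM).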

Compound 4, half-maximal inhibitory concentration: 54 nM
The estimate for compound 4 lay 1.1-fold (0.03 log units) below the measured number; measured number inside the range.
By their numbers in this assay, from the lowest: compounds 2, 4, 3 and 1 (each within the scatter of the next).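

Notes on the sulfonamide nitrogen: in this assay the exchange of pyrimidin-2-yl for pyridin-2-yl gives a 1.2-fold higher number from compound 2 to compound 4 (0.08 log units; within the scatter) and is the first measured step at this position. The number of hydrogen-bond acceptors on the group falls with this exchange, yet the step does not leave the scatter, so this pair shows that either six-membered aromatic ring can stand on this nitrogen without a readable change. No available evidence accounts for this result.

Still open, from the compounds shown here alone, is whether a plain phenyl ring, with no ring nitrogen, or a five-membered ring such as thiazol-2-yl would stay as close in this assay as this pair does. A bare sulfonamide hydrogen or a small acetyl group on the same nitrogen would test whether an aromatic ring is needed there at all.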